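Butyl in Place of Phenylsulfanyl on a Saturated Ring Carbon

The source may hold more compounds than are shown below. What is called first, only, known or untested is meant among the compounds shown, and "the series" means these compounds.

Compound 1 `CC1(Sc2ccccc2)C(=O)N(c2ccccc2)c2ncccc21` was tested in a functional assay on the whole organism (Pleural cavity) for inhibition, with Rattus norvegicus as the target, at a dose of 25 mg/kg (a lower number here means less inhibition, a higher number more inhibition at the dose given (going by the name of the read-out)), and compound 1 gives 0%, the lowest of the three numbers available. Compound 2 `CSc1ccc(N2C(=O)C(C)(C)c3cccnc32)cc1` gives 29% in this assay, and compound 3 `C[S+]([O-])c1ccc(N2C(=O)C(C)(C)c3cccnc32)cc1` gives 39%. Within the data shown here, the only measured step between close relatives is a number 10 percentage points higher from compound 2 to compound 3 (within the scatter), a change on an aromatic carbon of a side ring, not on the saturated ring carbon of the shared core.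

Compound 4 `CCCCC1(C)C(=O)N(c2ccccc2)c2ncccc21` differs from compound 1 by butyl in place of phenylsulfanyl on a saturated ring carbon. Among the measured compounds shown here, no measured pair changes the group on that saturated ring carbon, so the step from compound 2 to compound 3 bears on this change only distantly, and it was itself within the scatter. Because compound 1 sits at 0%, a downward move is not possible, and an upward one has no direct support. The estimate for compound 4 is therefore 10%, with a range from 0% to 35%, meaning an expected step of a number 10 percentage points higher from compound 1 to compound 4 (within the scatter).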

Compound 4, a percentage reported as inhibition, in the whole organism at one dose (the size of the read-out at that dose, not a potency): 21%
For compound 4 the middle estimate is 11 percentage points below the measured one, and the stated range covers the measured number.
By their numbers in this assay, from the lowest: compound 1; then compounds 4, 2 and 3 (each within the scatter of the next, the first and the last beyond it).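

Among these compounds, replacing phenylsulfanyl with butyl on the saturated ring carbon gives a number 21 percentage points higher from compound 1 to compound 4 (beyond the scatter) in this assay, so the first measured change at this position shows that the group there can alter the read-out. The phenylsulfanyl group and its aromatic ring are not needed for inhibition at this dose, since compound 4 has a butyl chain with no ring, sulfur or hydrogen-bond acceptor. No available evidence explains the difference between these two groups.

Butyl and phenylsulfanyl differ in several ways at once, so this single step cannot separate the contribution of the sulfur from that of the aromatic ring. Going by these compounds, it also remains open how a benzyl group, a longer chain, an amine or a carboxylic acid on the same carbon would compare.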